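The source may report more compounds than this note shows. Statements on the series, on what has been measured and on what is new or still open speak of the compounds shown alone.

Values in an ADME assay on Caco-2 cells (Homo sapiens) for permeability, read by LC-MS, in the apical to basolateral direction, with a stated time of 2 h, tested at 2 uM (a higher number here means that the compound crosses the layer faster, a lower number that the compound crosses the layer more slowly), follow
- compound 1 `CC[C@@H](Nc1c(C#N)c(-c2ccc(-c3cccc(C)c3F)cc2)nc2cnccc12)C(N)=O` gives 47 nm/s
- compound 2 `CC[C@@H](Nc1c(C#N)c(-c2ccc(-c3ccc(OC)cc3)cc2)nc2cnccc12)C(N)=O` gives 114 nm/s
- compound 3 `CCOc1ccccc1-c1ccc(-c2nc3cnccc3c(N[C@H](CC)C(N)=O)c2C#N)cc1` gives 151 nm/s

Compound 3 carries the highest of the three numbers, but it cannot be separated from its nearest neighbour (a 1.3-fold higher number from compound 2 to compound 3 (0.12 log units; within the scatter)). Its distance from the remaining compound is real (a 3.2-fold higher number from compound 1 to compound 3 (0.51 log units; beyond the scatter)).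

The next step leads to compound 4 `CC[C@@H](Nc1c(C#N)c(-c2ccc(-c3cccc(Cl)c3)cc2)nc2cnccc12)C(N)=O` and puts 3-chlorophenyl in place of 2-ethoxyphenyl on an aromatic carbon, para to a large group (3-chlorophenyl in place of 2-ethoxyphenyl on an aromatic carbon).

For the measured compounds named here, no measured step makes this exact exchange, so the evidence is indirect. Going by the values given here, compound 1 is the only measured compound whose terminal aromatic group has no oxygen, and it lies beyond the scatter from both others (a 2.4-fold higher number from compound 1 to compound 2 (0.38 log units; beyond the scatter) and a 3.2-fold higher number from compound 1 to compound 3 (0.51 log units; beyond the scatter)). Both steps are modest. Three compounds make thin support, and none of them goes against this reading. The 3-chlorophenyl group also has no oxygen, so a modest fall in this assay is expected, with compound 4 nearer to compound 1 than to compound 3.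

The expected change is a 2.2-fold lower number from compound 3 to compound 4 (0.33 log units; beyond the scatter) and could prove smaller. The estimated value for compound 4 is 70 nm/s (expected range 30 nm/s to 150 nm/s).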

Compound 4, apparent permeability: 37 nm/s
Beside the measured number, compound 4's estimate is 1.9-fold (0.28 log units) above it, within the range that was stated.
By their numbers in this assay, from the lowest: compounds 4 and 1 (each within the scatter of the next); then compounds 2 and 3 (each within the scatter of the next).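

In this assay, the 3-chlorophenyl group sits clearly apart from both oxygen-bearing groups, with a 4.1-fold lower number from compound 3 to compound 4 (0.61 log units; beyond the scatter) and a 3.1-fold lower number from compound 2 to compound 4 (0.49 log units; beyond the scatter), whereas a 1.3-fold lower number from compound 1 to compound 4 (0.10 log units; within the scatter) does not separate it from the other terminal aromatic group without oxygen. At this position, the division between compounds 2 and 3 on one side and compounds 1 and 4 on the other now rests on two different oxygen-free groups rather than one, and none of the four compounds goes against it, although four compounds are a narrow base for any pattern. Nothing available explains this division.

From the compounds shown here alone, whether the oxygen itself tracks with the division, or some other feature of these groups does, remains open: an unsubstituted phenyl, a 3-methoxyphenyl or a 2-ethoxyphenyl with an added chlorine would bear directly on that question. Going by these compounds, how an amine or a carboxylic acid on the terminal ring would fare also remains open, as does any change to the nitrile or the amide side chain, which all four compounds share.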